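This account rests on a few compounds, and the source may have more. Where it says the series, first, only, none or still open, it means among the compounds named here.

compound 1 `Cc1ccccc1S(=O)(=O)NC(C1=CC(=O)c2c(O)ccc(O)c2C1=O)C(C)C` gives 790 nM
compound 2 `CC(=O)c1ccc(S(=O)(=O)NC(C2=CC(=O)c3c(O)ccc(O)c3C2=O)C(C)C)cc1` gives 3820 nM
compound 3 `Cc1ccccc1S(=O)(=O)NC(C)C1=CC(=O)c2c(O)ccc(O)c2C1=O` gives 4490 nM

In a functional assay on HeLa cells (Homo sapiens) for cytotoxicity, read by sulforhodamine B assay (a higher number here means a weaker inhibitor, a lower number a stronger inhibitor), compound 3 stands at 4490 nM, within the scatter of compound 2. Both sit clearly above compound 1, so compound 3 belongs to the weaker end of this small set. Compound 4 `CC(NS(=O)(=O)c1ccc(F)cc1)C1=CC(=O)c2c(O)ccc(O)c2C1=O` keeps the core and the methyl of compound 3 and has 4-fluorophenyl in place of 2-methylphenyl on a sulfonyl sulfur.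

The closest guide is a 4.8-fold higher number from compound 1 to compound 2 (0.68 log units; beyond the scatter), a modest step that also replaces 2-methylphenyl on the sulfonyl sulfur, but with 4-acetylphenyl entering and isopropyl on the chain. The other measured step, a 5.7-fold higher number from compound 1 to compound 3 (0.75 log units; beyond the scatter), concerns the chain and not this group. Going by the values given here, no measured compound carries 4-fluorophenyl, so the guide is a loose one, and a smaller move in the same direction seems likely. The expected change is a 1.3-fold higher number from compound 3 to compound 4 (0.13 log units; within the scatter), probably not beyond the scatter. Compound 4 is estimated at 6000 nM, with an expected range of 2500 nM to 14000 nM.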

Compound 4, half-maximal inhibitory concentration: 6410 nM
The estimate for compound 4 lay 1.1-fold (0.03 log units) below the measured number; the range from low to high includes it.
By their numbers in this assay, from the lowest: compound 1; then compounds 2, 3 and 4 (each within the scatter of the next).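

In this assay, putting 4-fluorophenyl in place of 2-methylphenyl on a sulfonyl sulfur gives a 1.4-fold higher number from compound 3 to compound 4 (0.15 log units; within the scatter), so with methyl on the chain, this exchange of one substituted phenyl for another leaves the read-out unchanged within normal variation. The earlier step at the same place, a 4.8-fold higher number from compound 1 to compound 2 (0.68 log units; beyond the scatter), shows that a change here can matter, but it brought in a different group, 4-acetylphenyl, and had isopropyl on the chain, so the two steps are not a direct match. Nothing measured here explains the small size of the new step.

The compounds shown leave open whether 4-fluorophenyl would behave the same way with isopropyl on the chain. They also leave open how a phenyl ring carrying an amine or a carboxylic acid, or a longer chain in place of the methyl, would fare.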